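Swapping the Thiadiazole Sulfur for Oxygen in Compound 1

The compounds below may be only part of what the source reports. "The series", "measured", "known", "first", "only" and "open" are said of these compounds alone.

Of the compounds shown here, three have been tested in an assay on microsomes from liver for inhibition of acyl-CoA desaturase 1 (Rattus norvegicus); a lower number here means a stronger inhibitor, a higher number a weaker inhibitor. Compound 1 `OCc1nnc(-c2ccc(N3CCC(Oc4ccccc4C(F)(F)F)CC3)nn2)s1` gives 3.2 nM, the lowest of the three numbers. Compound 2 `COc1ccccc1OC1CCN(c2ccc(-n3ccnc3)nn2)CC1` gives 543 nM, and compound 3 `c1cc(OC2CCN(c3ccc(-n4ccnc4)nn3)CC2)c2cc[nH]c2c1` gives 162 nM. Going by the values given here, the only single-point comparison among the measured compounds is a 3.4-fold lower number from compound 2 to compound 3 (0.53 log units; beyond the scatter); that change sits on the aryl ether part of the shared core and leaves the other end of the molecule untouched.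

Compound 4 `OCc1nnc(-c2ccc(N3CCC(Oc4ccccc4C(F)(F)F)CC3)nn2)o1` differs from compound 1 in exactly one place: 5-(hydroxymethyl)-1,3,4-oxadiazol-2-yl in place of 5-(hydroxymethyl)-1,3,4-thiadiazol-2-yl on an aromatic carbon. Among the compounds with values here, no measured pair among the three compounds changes this five-membered ring, so none of the available steps bears directly on the move from compound 1 to compound 4. The new ring keeps the same count of heavy atoms, donors and acceptors as the one it replaces, with one atom exchanged inside the ring.

With nothing in the data to argue for a large shift, compound 4 is expected to stay close to compound 1, with the estimated step of a 1.9-fold higher number from compound 1 to compound 4 (0.27 log units; within the scatter) pointing toward a somewhat higher number. The estimate for compound 4 in this assay is 6 nM, within a range from 1.5 nM to 25 nM.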

Compound 4, half-maximal inhibitory concentration: 2.9 nM
Beside the measured number, compound 4's estimate is 2.1-fold (0.32 log units) above it, within the range that was stated.
By their numbers in this assay, from the lowest: compounds 4 and 1 (each within the scatter of the next); then compound 3; then compound 2.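

In this assay, exchanging the ring sulfur for oxygen gives a 1.1-fold lower number from compound 1 to compound 4 (0.04 log units; within the scatter), so on this aromatic carbon of the six-membered aromatic ring with 2 nitrogen, this read-out does not tell the 5-(hydroxymethyl)-1,3,4-thiadiazol-2-yl group from the 5-(hydroxymethyl)-1,3,4-oxadiazol-2-yl group. Going by these compounds alone, this is the only measured pair that changes the five-membered ring, whereas the other step changes only the aryl ether end, and it shows that a number as low as that of compound 1 does not require the ring sulfur. Nothing available explains why the exchange leaves the number within the scatter.

Whether the number would hold with an amine, a carboxylic acid or a longer chain in place of the hydroxymethyl group on the ring remains an open question. Within the data shown here, compound 2 and compound 3 carry a different group at this position and a different aryl ether as well, so no step from either of them to compound 1 or compound 4 can be read, and the contribution of the five-membered ring itself stays unsettled.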